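From Hydroxymethyl to 2-Hydroxyethyl on a Shared Core

This account rests on a few compounds, and the source may have more. Where it says the series, first, only, none or still open, it means among the compounds named here.

Three measured compounds share one core and were read in an ADME assay on TZM-b1 cells (Homo sapiens) for cytotoxicity, read by XTT assay, with a stated time of 3 days; on this read-out higher numbers stand for lower toxicity in this test and lower numbers for higher toxicity in this test. Compound 1 `Cc1ccc(NC(=O)C(=O)NC(c2nc(C)c(CCO)s2)C2CCCCN2)cc1F` gives > 85000 nM, which is a limit of the test and not a number. Compound 2 `Cc1ccc(NC(=O)C(=O)NC(c2nc(C)c(CCO)s2)C2CCCCN2)c(F)c1` gives > 78800 nM, also a limit. For the measured compounds named here, compound 3 `Cc1nc(C(NC(=O)C(=O)Nc2ccc(Cl)c(F)c2)C2CCCCN2)sc1CO` gives 58400 nM, the only plain number of the three. The step from compound 1 to compound 2 in this assay is a step that the two limits leave unreadable from compound 1 to compound 2 and says nothing about the change at hand. Compound 4 `Cc1nc(C(NC(=O)C(=O)Nc2ccc(Cl)c(F)c2)C2CCCCN2)sc1CCO` differs from compound 3 by hydroxymethyl in place of hydroxy on a saturated chain carbon bound to an aromatic carbon. Going by the values given here, no measured step covers this change; compounds 1 and 2, which carry the 2-hydroxyethyl chain, sit at limits. The expected step from compound 3 to compound 4 is therefore a 1.2-fold higher number from compound 3 to compound 4 (0.08 log units; within the scatter), within the scatter. Compound 4 is expected to give about 70000 nM, between 35000 nM and 140000 nM.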

Compound 4, half-maximal cytotoxic concentration: 61000 nM
Compound 4: the middle estimate sits 1.1-fold (0.06 log units) above what was measured; measured number inside the range.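

On the shared core with the 4-chloro-3-fluorophenyl group, hydroxymethyl and 2-hydroxyethyl can now be compared as plain numbers in this assay, and the two cannot be told apart (a 1.0-fold higher number from compound 3 to compound 4 (0.02 log units; within the scatter)). Compound 1 and compound 2 stand at limits of the test, so the changes on the aromatic ring give only floors (an at least 1.2-fold lower number from compound 2 to compound 4 (0.11 log units; that floor lies within the scatter)) and (an at least 1.3-fold lower number from compound 1 to compound 4 (0.14 log units; that floor lies within the scatter)). Nothing shown gives a cause for these readings. Going by these compounds, whether a longer chain, or an amine or a carboxylic acid in place of the hydroxy, would read the same remains open.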